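The source may report more compounds than this note shows. Statements on the series, on what has been measured and on what is new or still open speak of the compounds shown alone.

Measured in a functional assay on the whole organism for positive allosteric modulation, with Rattus norvegicus as the target; a lower number here means that less compound is needed, a higher number that more compound is needed for the effect:

compound 1 `Cc1nn(C)c2c1C(c1ccccc1)=NCCN2`, 2.5 mg/kg
compound 2 `Cc1nn(C)c2c1C(c1ccccc1)=NCCN2C`, 2.5 mg/kg
compound 3 `Cc1nn(C)c2c1C(c1cccc(O)c1)=NCCN2`, 2.5 mg/kg

All three sit at the same reading. The change methyl in place of hydrogen on a nitrogen on an aromatic ring in a ring gives no change at the digits printed from compound 1 to compound 2 (within the scatter), and the change hydroxy in place of hydrogen on an aromatic carbon gives no change at the digits printed from compound 1 to compound 3 (within the scatter); neither alteration of the core of compound 1 moves the minimum effective dose.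

Compound 4 `Cc1nn(C)c2c1C(c1ccc(O)cc1)=NCCN2C` is not yet measured. It differs from compound 2 by hydroxy in place of hydrogen on an aromatic carbon. For the measured compounds named here, this is the same kind of change as the one from compound 1 to compound 3, though not the same: in compound 3 the hydroxy sits meta to a large group, in compound 4 it sits para to a large group. The two cores differ by methyl in place of hydrogen on a nitrogen on an aromatic ring in a ring.

Because no change at the digits printed from compound 1 to compound 3 (within the scatter) is within the scatter and no change at the digits printed from compound 1 to compound 2 (within the scatter) is also within the scatter, the step from compound 2 to compound 4 is expected to be no change at the digits printed from compound 2 to compound 4 (within the scatter), a size comparable to the earlier hydroxy step. As far as these compounds go, for compound 4 the expected value in this assay is 2.5 mg/kg, with a likely range from 1.2 mg/kg to 5 mg/kg; the para placement is untested, so the range is kept open.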

Compound 4, minimum effective dose: 2.5 mg/kg
For compound 4 middle estimate and measured number coincide at the digits printed; the range from low to high includes it.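

In this assay, hydroxy in place of hydrogen on an aromatic carbon gives no change at the digits printed from compound 2 to compound 4 (within the scatter), and the step carries from one core to the other without a difference beyond the scatter: the same change on two cores in this assay, no change at the digits printed (within the scatter) from compound 1 to compound 3 and no change at the digits printed (within the scatter) from compound 2 to compound 4, 1.0-fold (0.00 log units) apart, within the scatter of two such steps

This holds only for the two cores shown and for a single substituent, and in compound 4 the hydroxy sits para to a large group, so the two steps are not strictly the same change. With all four compounds level at the digits printed, the series shows that the hydroxy step is tolerated on both cores, but it cannot show how a step that moves the minimum effective dose would carry over.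

As far as these compounds go, it remains open whether a carboxylic acid or an amine on the same aromatic ring would shift the reading in this assay. The same question applies to a longer chain in place of the methyl on the ring nitrogen of compound 2.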